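From 3,5-dimethylphenyl to 4-chloro-2-methylphenyl

The source may report more compounds than this note shows. Statements on the series, on what has been measured and on what is new or still open speak of the compounds shown alone.

In a functional assay on HeLa cells (Homo sapiens) for antiproliferative activity, read by spectrophotometry, with a stated time of 2 days (a higher number here means a weaker inhibitor of growth, a lower number a stronger inhibitor of growth), compound 2 `Cc1cc(C)cc(Nc2ncc(C(F)(F)F)c(N3Cc4cccc(N(C)S(C)(=O)=O)c4C3)n2)c1` gives > 30000 nM as its reading, which is a limit of the assay and not a number. Going by the values given here, compound 1 `COc1ccc(C(F)(F)F)cc1Nc1ncc(C(F)(F)F)c(N2Cc3cccc(N(C)S(C)(=O)=O)c3C2)n1` is the only other measured compound and gives 17200 nM in this assay as a true number. Compound 3 `Cc1cc(Cl)ccc1Nc1ncc(C(F)(F)F)c(N2Cc3cccc(N(C)S(C)(=O)=O)c3C2)n1` keeps the shared core and carries 4-chloro-2-methylphenyl in place of 3,5-dimethylphenyl on a nitrogen on an aromatic ring. Among the compounds with values here, one measured step bears on this change, since it falls at the same place: an at least 1.7-fold higher number from compound 1 to compound 2 (0.24 log units; that floor lies within the scatter) was the size recorded there. That step exchanged a different pair of groups and its floor lies within the scatter, so it offers no direction for the new change. Compound 3 is therefore expected to stay as weak a growth inhibitor as the two measured compounds, and it may also end at the assay limit. The expected at least 1.2-fold lower number from compound 2 to compound 3 (0.09 log units; that floor lies within the scatter) is no step beyond the scatter. The estimate for compound 3 is 24000 nM within a range of 10000 nM to 45000 nM in this assay overall.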

Compound 3, concentration for 50% growth inhibition: 17400 nM
For compound 3 the middle estimate is 1.4-fold (0.14 log units) above the measured one, and the stated range covers the measured number.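

Compound 2 remains a limit of the assay and not a number: the limit of > 30000 nM in this assay, at which 1 of the 3 values shown sits.

Going by these compounds, compound 3 gives this place on the aromatic nitrogen a second true reading alongside compound 1, and putting 4-chloro-2-methylphenyl in place of 3,5-dimethylphenyl gives an at least 1.7-fold lower number from compound 2 to compound 3 (0.23 log units; that floor lies within the scatter), so in this assay the real size of this change stays unknown and only its floor can be read. The comparison with compound 1 is firmer: a 1.0-fold higher number from compound 1 to compound 3 (0.01 log units; within the scatter), which shows that 4-chloro-2-methylphenyl and 2-methoxy-5-(trifluoromethyl)phenyl read alike on this nitrogen, even though the two groups share only a six-membered aromatic ring of carbon.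

The compounds shown leave open whether a phenyl carrying an amine or a carboxylic acid, or a cyclohexyl in place of the aromatic ring, would move the reading clearly away from these values. The chlorine and the methyl of compound 3 also cannot be told apart, as both enter together in a single step.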